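The source may report more compounds than this note shows. Statements on the series, on what has been measured and on what is new or still open speak of the compounds shown alone.

Compounds measured in a functional assay on A498 cells (Homo sapiens) for antiproliferative activity, read by sulforhodamine B assay, with a stated time of 48 h; on this read-out lower numbers stand for stronger inhibition of growth and higher numbers for weaker inhibition of growth:
- compound 1, `Nc1nn(C(=O)Nc2ccc(Cc3ccccc3)cc2)c2ccccc12`: 31500 nM
- compound 2, `Nc1nn(C(=O)Nc2ccc(Cc3ccccc3)cc2)c2ccc(Cl)cc12`: 60700 nM

Compound 2 has the highest of the two numbers, and its nearest neighbour is compound 1, a gap that is within the scatter. Compound 3, `Nc1ccc2c(c1)c(N)nn2C(=O)Nc1ccc(Cc2ccccc2)cc1`, differs from compound 2 by amino in place of chloro on an aromatic carbon. Within the data shown here, the one measured step, a 1.9-fold higher number from compound 1 to compound 2 (0.28 log units; within the scatter), exchanged hydrogen for chloro at the same place and stayed within the scatter. Among the measured compounds shown here, the present step swaps chloro for amino, a change for which no measured pair exists, so the expectation rests on the observation that the one substituent change at this place moved the number little. Compound 3 is therefore expected to give roughly 45000 nM in this assay, most likely between 15000 nM and 110000 nM. That estimate means an expected step of a 1.3-fold lower number from compound 2 to compound 3 (0.13 log units; within the scatter), not beyond the scatter.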

Compound 3, concentration for total growth inhibition: 28400 nM
The estimate for compound 3 lay 1.6-fold (0.20 log units) above the measured number; low and high end bracket the measured number.
By their numbers in this assay, from the lowest: compounds 3, 1 and 2 (each within the scatter of the next, the first and the last beyond it).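

Among these compounds, replacing chloro with amino on this aromatic carbon in this assay gave a 2.1-fold lower number from compound 2 to compound 3 (0.33 log units; beyond the scatter) and so produced the first step at this place that lies beyond the scatter, though a modest one. Measured against hydrogen, amino gave a 1.1-fold lower number from compound 1 to compound 3 (0.04 log units; within the scatter) and stayed within the scatter, as chloro did, so the two substituents stand apart from each other while neither stands apart from compound 1. No evidence is at hand on what lies behind this small separation.

As far as these compounds go, it remains open whether a methoxy, a hydroxyl or an acetamide group on this carbon would move the number further than amino does or stay within the scatter of compound 1. From the compounds shown here alone, it is also open whether amino would give a similar result on another carbon of this ring.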